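From Phenyl to 3-Methylphenyl: Compound 3 to Compound 4

The compounds below may be only part of what the source reports. "The series", "measured", "known", "first", "only" and "open" are said of these compounds alone.

Compound 1 `Cc1ccc2occ(C(=O)Nc3ccccc3)c(=O)c2c1` gives 21.4 nM in an assay on cells for inhibition of Amine oxidase [flavin-containing] B (Homo sapiens), read by fluorescence and Amplex Red, using microsomes, with a stated time of 15 min; a higher number here means a weaker inhibitor, a lower number a stronger inhibitor.
Compound 2 `Cc1cccc(NC(=O)c2coc3ccc(C)cc3c2=O)c1` gives 17.1 nM in this assay.
Compound 3 `COc1ccc2occ(C(=O)Nc3ccccc3)c(=O)c2c1` gives 41.8 nM in this assay.

Compound 3 carries the highest of the three numbers. Its nearest neighbour is compound 1, reached by a 2.0-fold higher number from compound 1 to compound 3 (0.29 log units; within the scatter), a change that stays within the scatter. Going by the values given here, the gap to compound 2, which differs from compound 3 in two places and for which no single step is known, lies beyond the scatter.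

Compound 4 `COc1ccc2occ(C(=O)Nc3cccc(C)c3)c(=O)c2c1` is compound 3 with one change: methyl in place of hydrogen on an aromatic carbon. The same change has been made once before, on compound 1, giving compound 2, and there it read a 1.3-fold lower number from compound 1 to compound 2 (0.10 log units; within the scatter), a shift within the scatter. Among the compounds with values here, that one step is the only measured guide, and it points to no movement beyond the scatter in this assay when the methyl is added to compound 3.

Compound 4 is therefore expected to show a 1.2-fold lower number from compound 3 to compound 4 (0.09 log units; within the scatter) in this assay. Within the data shown here, the estimate for compound 4 is 34 nM, with a range from 15 nM to 80 nM, because the only comparable step, a 1.3-fold lower number from compound 1 to compound 2 (0.10 log units; within the scatter), was small.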

Compound 4, half-maximal inhibitory concentration: 21.8 nM
Compound 4: middle estimate off by 1.6-fold (0.19 log units), on the high side, and the stated range covers the measured number.
By their numbers in this assay, from the lowest: compounds 2, 1, 4 and 3 (each within the scatter of the next, the first and the last beyond it).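

The phenyl to 3-methylphenyl change now reads a 1.9-fold lower number from compound 3 to compound 4 (0.28 log units; within the scatter), a second reading of this methyl in this assay, and the two readings agree within the scatter: the same change on two cores in this assay, a 1.3-fold lower number (0.10 log units; within the scatter) from compound 1 to compound 2 and a 1.9-fold lower number (0.28 log units; within the scatter) from compound 3 to compound 4, 1.5-fold (0.19 log units) apart, within the scatter of two such steps

The methoxy in place of methyl change, earlier seen only with an unsubstituted phenyl, can now also be read with the 3-methylphenyl group in place, as a 1.3-fold higher number from compound 2 to compound 4 (0.11 log units; within the scatter), and this reading too agrees with the earlier one: the same change on two cores in this assay, a 2.0-fold higher number (0.29 log units; within the scatter) from compound 1 to compound 3 and a 1.3-fold higher number (0.11 log units; within the scatter) from compound 2 to compound 4, 1.5-fold (0.19 log units) apart, within the scatter of two such steps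

All four single steps among these compounds thus stay within the scatter, so neither the methyl on the aromatic carbon of the phenyl nor the exchange of methyl for methoxy on the shared core can, taken alone, be said to move the number in this assay.

What an amine or a carboxylic acid would do in place of this methyl stays open, since the only group shown at this position is methyl. The compounds also leave open how a chlorine atom or a longer chain would read in place of the methyl or methoxy on the shared core.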